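This account rests on a few compounds, and the source may have more. Where it says the series, first, only, none or still open, it means among the compounds named here.

Compound 1 `COc1ccc(-c2cs/c(=N/NC(=O)CSc3nnnn3C)n2-c2ccccc2)cc1` is the compound with the lowest number of the two measured here. In an ADME assay on NIH3T3 cells (Mus musculus) for cytotoxicity, read by MTT assay, with a stated time of 24 h (on this read-out higher numbers stand for weaker inhibition and lower numbers for stronger inhibition), compound 1 gives 45 ug/mL. Among the measured compounds shown here, its companion, compound 2 `Cn1nnnc1SCC(=O)N/N=c1/scc(-c2ccccc2)n1-c1ccccc1`, gives 173 ug/mL in this assay, and the one measured step, a 3.8-fold higher number from compound 1 to compound 2 (0.58 log units; beyond the scatter), comes from hydrogen in place of methoxy on an aromatic carbon.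

Compound 3 `COc1ccc(-c2cs/c(=N/NC(=O)CSc3nncn3C)n2-c2ccccc2)cc1` has not been measured. It differs from compound 1 by 4-methyl-4H-1,2,4-triazol-3-yl in place of 1-methyl-1H-tetrazol-5-yl on a sulfur, while the methoxy group of compound 1 stays in place. For the measured compounds named here, no measured step touches this part of the molecule, so the size of the change cannot be read from the measured pair. With no guide from the measured compounds, no step beyond the scatter is expected from compound 1 to compound 3, and the expected step is a 1.1-fold higher number from compound 1 to compound 3 (0.05 log units; within the scatter). Compound 3 is therefore estimated at 50 ug/mL in this assay, within a range of 20 ug/mL to 130 ug/mL.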

Compound 3, half-maximal inhibitory concentration: 167 ug/mL
Estimate against measurement, compound 3: 3.3-fold (0.52 log units) below, outside the stated range (above it).
By their numbers in this assay, from the lowest: compound 1; then compounds 3 and 2 (each within the scatter of the next).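

The ring on the sulfur is a second place where the number moves in this assay: 4-methyl-4H-1,2,4-triazol-3-yl in place of 1-methyl-1H-tetrazol-5-yl gives a 3.7-fold higher number from compound 1 to compound 3 (0.57 log units; beyond the scatter), with the methoxy group left in place. The two groups have the same count of heavy atoms and differ only in one ring nitrogen exchanged for a carbon, so even this small exchange on the sulfur weakens inhibition beyond the scatter. Nothing shown here explains the size or direction of this step.

From the compounds shown here alone, what stays open is how the methoxy change and the ring change act together in one molecule. Also open, going by these compounds, is how a different group on the sulfur, such as a pyridine ring, a plain ethyl chain or a carboxylic acid, would compare with these two rings.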